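A Larger Group on Compound 1

A few compounds are considered here, and "the series" means these few. Any claim that something is new, unique, unknown or untested is made for them only; others in the source may bear on it.

A compound's survival in liver preparations is an early measure of how long it might last in the body. Three related compounds have been tested in an ADME assay on microsomes from liver (Rattus norvegicus) for metabolic stability, read by LC-MS, using NADPH, with a stated time of 60 min, tested at 0.1 uM; on this read-out lower numbers stand for a less stable compound and higher numbers for a more stable compound. Compound 1 `Fc1ccc(Nc2cc3[nH]c(Nc4cc(N5CCNCC5)ccn4)nc3cn2)cc1C(F)(F)F` gives 73%, and compound 3 `C[C@@H]1CN(c2ccc(Nc3nc4cnc(Nc5ccc(F)c(F)c5)cc4[nH]3)nc2)C[C@H](C)N1` gives 66%, two numbers within the usual scatter of each other. Compound 2 `C[C@H]1CN(c2ccc(Nc3nc4cnc(Nc5cccc(C(F)(F)F)c5)cc4[nH]3)nc2)CCN1` gives 53%, lower than compound 1 by more than the scatter. Compound 1 therefore sits level with compound 3 and clearly above compound 2.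

Compound 4 `O=C(c1ccnc(Nc2nc3cnc(Nc4ccc(F)c(C(F)(F)F)c4)cc3[nH]2)c1)N1CCN(C2CC2)CC1` has not yet been measured. It has (4-cyclopropylpiperazin-1-yl)carbonyl in place of piperazin-1-yl on an aromatic carbon, and the rest of compound 1 stays the same: (4-cyclopropylpiperazin-1-yl)carbonyl in place of piperazin-1-yl on an aromatic carbon. The entering group is the larger one, and it adds a three-membered ring of carbon only.

Among the compounds with values here, no two measured compounds differ in just one place, so the data give no direct guide to the size of this change. Still, compound 2 at 53% shows how far a close relative can lie from compound 1. The expected change is a modest fall, a little beyond the scatter: a number 13 percentage points lower from compound 1 to compound 4 (beyond the scatter). For compound 4 the estimate is 60%, with an expected range from 40% to 80%.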

Compound 4, percent of the compound remaining: 53%
Compound 4: the middle estimate sits 7 percentage points above what was measured; measured number inside the range.
By their numbers in this assay, from the lowest: compounds 2 and 4 (each within the scatter of the next); then compounds 3 and 1 (each within the scatter of the next).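

Within the data shown here, putting (4-cyclopropylpiperazin-1-yl)carbonyl in place of piperazin-1-yl on this aromatic carbon, opposite the ring nitrogen, gives a number 20 percentage points lower from compound 1 to compound 4 (beyond the scatter) in this assay and provides the first comparison here in which only one place changes. This shows that the position is not indifferent to its group: survival in the liver preparation shifts by more than ordinary scatter when the larger group enters, bringing a carbonyl and a three-membered carbon ring and removing the hydrogen-bond donor counted on the piperazin-1-yl group. No measurement at hand assigns the fall to any one of these features.

The compounds shown leave open whether the carbonyl, the cyclopropyl ring or the two together account for the step. A piperazine joined through the same carbonyl but lacking the cyclopropyl ring, or a 4-cyclopropylpiperazin-1-yl group attached directly to this aromatic carbon, would separate those two parts, while a simple open-chain amine on that carbon would test whether a piperazine ring is needed at all.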